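Stereo change at the limit of the cytotoxicity read-out

The compounds below may be only part of what the source reports. "The series", "measured", "known", "first", "only" and "open" are said of these compounds alone.

Measured compounds (an ADME assay on L1210/0 cells (Mus musculus) for cytotoxicity, with a stated time of 48 h; a lower number here means a stronger inhibitor, a higher number a weaker inhibitor):
- Compound 1 `O=c1[nH]cnc2c1nnn2C1C[C@H](CO)[C@@H](CO)[C@@H]1CO` - > 200000 nM (a limit of the assay, not a number)
- Compound 2 `CC(=O)OC(C)Cn1cnc2c(=S)[nH]c(N)nc21` - 128000 nM
- Compound 3 `O=C(CI)NCc1cn([C@H]2C[C@H](O)[C@@H](CO)O2)c(=O)[nH]c1=O` - 107000 nM

Compound 1 has no numerical value, only a limit (the limit of > 200000 nM in this assay, at which 1 of the 3 values shown sits). Going by the values given here, compounds 2 and 3 do give numbers, and these show weak inhibition in this assay, but their structures are unrelated to compound 1 and offer no step to build on.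

The next compound is compound 4 `O=c1[nH]cnc2c1nnn2[C@@H]1C[C@H](CO)[C@@H](CO)[C@H]1CO`. It has the same atoms and bonds as compound 1, and only the drawn stereochemistry differs (the two compounds have the same atoms and bonds; at least one stereo element is drawn with a configuration in one of them and without one in the other: 2 of 4 stereo elements differ; a stereocentre at a saturated ring carbon is drawn without a configuration in compound 1 and R in compound 4; a stereocentre at a saturated ring carbon is drawn S in compound 1 and R in compound 4). One stereocentre at a saturated ring carbon is drawn without a configuration in compound 1 and R in compound 4. Another is drawn S in compound 1 and R in compound 4.

Among the compounds with values here, no measured pair shows what a change of this kind does. The expectation therefore rests only on the limit of compound 1 (> 200000 nM). No step beyond the scatter is expected in either direction, and compound 4 may well also return only a limit. The estimate means an expected a number no higher from compound 1 to compound 4 (the limit leaves the size open) in this assay. For compound 4 the estimated value is 200000 nM, with an expected range from 90000 nM to 400000 nM.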

Compound 4, half-maximal inhibitory concentration: > 200000 nM
Compound 4: no number, only a limit (the forecaster's own chance of this, stated with the estimate: 70%); the middle value lies on the limit itself.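

In this assay, going by these compounds alone, compound 4 gives > 200000 nM, a limit and not a number, as compound 1 also does, so no step between compound 1 and compound 4 can be read. Left open is whether the stereo change at the two saturated ring carbons has any effect on the read-out, since neither compound has a numerical value.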